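Phenyl in place of the oxazolidinone on the core

The source may hold more compounds than are shown below. What is called first, only, known or untested is meant among the compounds shown, and "the series" means these compounds.

Compound 1 `O=C1Nc2ccc(N3CCOC3=O)cc2C(CNC(=O)c2ccc(F)cc2)(C(F)(F)F)O1` gives 67 nM in an assay for inhibition of very long chain fatty acid elongase 6 (Homo sapiens) (a lower number here means a stronger inhibitor, a higher number a weaker inhibitor), the second highest of the three numbers to hand. Compound 3 `Cc1ccc(C(=O)NCC2(C(F)(F)F)OC(=O)Nc3ccc(Cl)cc32)cc1` gives 38 nM, within the scatter of compound 1, while compound 2 `O=C1Nc2ccc(Cl)cc2C(CNC(=O)c2ccccc2F)(C(F)(F)F)O1` gives 539 nM, beyond it. Compound 4 `O=C1Nc2ccc(-c3ccccc3)cc2C(CNC(=O)c2ccc(F)cc2)(C(F)(F)F)O1` carries phenyl in place of 2-oxo-1,3-oxazolidin-3-yl on an aromatic carbon. Going by the values given here, the only single-place step available, a 14-fold lower number from compound 2 to compound 3 (1.15 log units; beyond the scatter), alters the group on the carbonyl carbon and not the substituent on the core, so it does not bear on this change. Compounds 2 and 3 carry a different group on the core yet also differ from compound 1 at the amide, so the weight of the core substituent alone cannot be separated. No step beyond the scatter is therefore expected from compound 1 to compound 4, a 1.0-fold higher number from compound 1 to compound 4 (0.02 log units; within the scatter). Compound 4 is estimated at 70 nM, with a range of 25 nM to 200 nM.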

Compound 4, half-maximal inhibitory concentration: 1480 nM
Beside the measured number, compound 4's estimate is 21-fold (1.33 log units) below it, and the stated range ends below it.
By their numbers in this assay, from the lowest: compounds 3 and 1 (each within the scatter of the next); then compound 2; then compound 4.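

Going by these compounds alone, on the shared core, this aromatic carbon does not tolerate every six-atom substituent: phenyl in place of 2-oxo-1,3-oxazolidin-3-yl gives a 22-fold higher number from compound 1 to compound 4 (1.34 log units; beyond the scatter) in this assay, the first reading of this position with the amide held fixed. The two groups match in heavy-atom count, so that count alone does not set the value here. No measurement to hand accounts for the loss.

Going by these compounds, whether the hydrogen-bond acceptors or the non-aromatic ring matters stays open; a morpholine ring or a methoxy group at this carbon would help separate them. On these data alone, whether the step carries over to other amides is also open.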